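Replacing the 2-aminophenyl end of compound 3 with hydroxy

The source may hold more compounds than are shown below. What is called first, only, known or untested is meant among the compounds shown, and "the series" means these compounds.

Of the compounds shown here, three have been read in a functional assay on NCI-H460 cells (Homo sapiens) for inhibition, read by CCK-8 assay, with a stated time of 72 h; a higher number here means a weaker inhibitor, a lower number a stronger inhibitor. Compound 1 `Nc1ccccc1NC(=O)c1ccc(CNC(=O)c2n[nH]cc2NC(=O)c2ccccc2)cc1` gives 6320 nM, compound 2 `O=C(NO)c1ccc(CNC(=O)c2n[nH]cc2NC(=O)c2c(Cl)cccc2Cl)cc1` gives 10600 nM and compound 3 `Nc1ccccc1NC(=O)c1ccc(CNC(=O)c2n[nH]cc2NC(=O)c2ccccc2F)cc1` gives 9990 nM. All three numbers lie within the usual scatter of one another, so compound 3 cannot be ranked against the other two.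

Compound 4 `O=C(NO)c1ccc(CNC(=O)c2n[nH]cc2NC(=O)c2ccccc2F)cc1` has not yet been measured. It departs from compound 3 in one place: hydroxy in place of 2-aminophenyl on an amide-type nitrogen. In words, this is hydroxy in place of 2-aminophenyl on an amide-type nitrogen.

Among the compounds with values here, no measured step makes this exchange. Within the data shown here, the only measured step, a 1.6-fold higher number from compound 1 to compound 3 (0.20 log units; within the scatter), is fluoro in place of hydrogen on an aromatic carbon, a feature that compound 4 also carries, so it does not size the exchange. The closest evidence is compound 2, which has the same hydroxycarbamoyl end but a different halogen pattern. Compound 2 gives 10600 nM and compound 3 gives 9990 nM, two values within the scatter of each other.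

On that indirect evidence, no change beyond the scatter is expected, and the estimated step is a 1.3-fold lower number from compound 3 to compound 4 (0.12 log units; within the scatter). For compound 4 the estimated value is 7500 nM, with an expected range of 2000 nM to 22000 nM.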

Compound 4, half-maximal inhibitory concentration: 23700 nM
For compound 4 the middle estimate is 3.2-fold (0.50 log units) below the measured one; measured number above the stated range.
By their numbers in this assay, from the lowest: compounds 1, 3 and 2 (each within the scatter of the next); then compound 4.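

At the amide-type nitrogen, hydroxy in place of 2-aminophenyl is not a neutral exchange: this assay records a 2.4-fold higher number from compound 3 to compound 4 (0.38 log units; beyond the scatter) with the 2-fluorophenyl group held constant, a modest move toward weaker inhibition. With the hydroxycarbamoyl end held constant, the other end of the molecule also matters, since 2-fluorophenyl in place of 2,6-dichlorophenyl on a carbonyl carbon gives a 2.2-fold higher number from compound 2 to compound 4 (0.35 log units; beyond the scatter) and is likewise a modest move toward weaker inhibition. The earlier step, a 1.6-fold higher number from compound 1 to compound 3 (0.20 log units; within the scatter) within the 2-aminophenyl compounds, had shown no change beyond the scatter, so these are the first steps here to separate compounds clearly. Nothing available here accounts for either new step.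

The compounds shown leave open whether hydroxy in place of 2-aminophenyl has a step of the same size when the far end carries phenyl or 2,6-dichlorophenyl instead of 2-fluorophenyl. They also leave open how a smaller change at the far end, such as 2-chlorophenyl, or a simple methyl on the amide-type nitrogen would read in this assay alongside these compounds.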